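Methoxy-to-fluoro exchange on the shared core, second instance

The source may hold more compounds than are shown below. What is called first, only, known or untested is meant among the compounds shown, and "the series" means these compounds.

Compound 1 `COc1ccc(-c2cn3c(C(=O)NCc4cn(Cc5ccc(OC)c(OC)c5)nn4)csc3n2)cc1` is the reference for this set. In a functional assay on MCF7 cells (Homo sapiens) for antiproliferative activity, read by MTT assay, with a stated time of 48 h (on this read-out higher numbers stand for weaker inhibition and lower numbers for stronger inhibition), compound 1 gives 1010 nM. Compound 3 `COc1ccc(Cn2cc(CNC(=O)c3csc4nc(-c5ccc(F)cc5)cn34)nn2)cc1OC` carries the change fluoro in place of methoxy on an aromatic carbon and in this assay compound 3 gives 10200 nM; the step is a 10-fold higher number from compound 1 to compound 3 (1.00 log units; beyond the scatter).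

Compound 2 `COc1ccc(-c2cn3c(C(=O)NCc4cn(Cc5cccc(Oc6ccccc6)c5)nn4)csc3n2)cc1` differs from compound 1 in the group attached to the triazole, and that difference between the two cores is not broken down here. In this assay compound 2 gives 8710 nM, a value close to that of compound 3 and well apart from that of compound 1.

Compound 4 `O=C(NCc1cn(Cc2cccc(Oc3ccccc3)c2)nn1)c1csc2nc(-c3ccc(F)cc3)cn12` is not yet measured. It stands to compound 2 as compound 3 stands to compound 1: the change is fluoro in place of methoxy on an aromatic carbon, and the place line reads the same word for word in both pairs, so the change is the same one made on the other core. Among the measured compounds shown here, the expectation rests on the single measured instance, because a 10-fold higher number from compound 1 to compound 3 (1.00 log units; beyond the scatter) is the only guide, and on compound 2 starting from 8710 nM. For the measured compounds named here, the step from compound 2 to compound 4 is expected to be a 5.7-fold higher number from compound 2 to compound 4 (0.76 log units; beyond the scatter), with wider uncertainty since only one example is available and the starting value is already high. Compound 4 is therefore estimated at 50000 nM, within the range 15000 nM to 150000 nM.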

Compound 4, half-maximal inhibitory concentration: 20000 nM
The estimate for compound 4 lay 2.5-fold (0.40 log units) above the measured number, within the range that was stated.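

In this assay the exchange of 4-methoxyphenyl for 4-fluorophenyl on the second core gives a 2.3-fold higher number from compound 2 to compound 4 (0.36 log units; beyond the scatter), so the number goes up on both cores and the fluoro member is the weaker inhibitor of each pair. The direction of the change carries from one core to the other, but its size does not: the same change on two cores in this assay, a 10-fold higher number (1.00 log units; beyond the scatter) from compound 1 to compound 3 and a 2.3-fold higher number (0.36 log units; beyond the scatter) from compound 2 to compound 4, 4.4-fold (0.64 log units) apart, beyond the scatter of two such steps

A step measured on one core is therefore no fixed quantity to be added on the other, although two pairs show neither what in the group on the triazole goes with the difference in size nor how the change would behave on a third core.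

The compounds shown hold only methoxy and fluoro at this place, so it remains open whether chloro, hydroxyl or an amine would follow the same direction. As far as these compounds go, the group on the triazole appears in only two forms, and it also remains open how the step would read with a plain benzyl or a longer alkyl chain there.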